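Furan-3-yl for thiophen-3-yl at the saturated ring carbon

This account rests on a few compounds, and the source may have more. Where it says the series, first, only, none or still open, it means among the compounds named here.

Measured so far in an assay on cells for displacement of a labelled ligand from adenosine receptor A1 (Homo sapiens), with a stated time of 60 min, tested at 1 uM; on this read-out lower numbers stand for less inhibition and higher numbers for more inhibition at the one concentration tested (going by the name of the read-out):
compound 1 `CC1=C(C(=O)OC(C)C)C(C2CCCC2)N/C(=N/C#N)N1` gives 3%
compound 2 `CC1=C(C(=O)OC(C)C)C(c2ccsc2)N/C(=N/C#N)N1` gives 11%
compound 3 `CCOC(=O)C1=C(C)N/C(=N\C#N)NC1c1ccsc1` gives 29%

Compound 3 stands highest of the three numbers, with compound 2 next and compound 1 furthest, both steps to compound 3 beyond the scatter. Compound 4 `CCOC(=O)C1=C(C)N/C(=N\C#N)NC1c1ccoc1` differs from compound 3 in one place: furan-3-yl in place of thiophen-3-yl on a saturated ring carbon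

Among the measured compounds shown here, the only measured step at this same place, a number 8 percentage points higher from compound 1 to compound 2 (within the scatter), swaps a ring on that carbon and stays within the scatter. The step of a number 18 percentage points higher from compound 2 to compound 3 (beyond the scatter) changes the ester and does not bear on the ring swap. A step within the scatter is therefore expected for compound 4 in this assay, a number 3 percentage points lower from compound 3 to compound 4 (within the scatter). Compound 4 is estimated at 26%, between 10% and 42%.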

Compound 4, a percentage reported as inhibition, at one concentration (the size of the read-out at that concentration, not a potency): 28%
Compound 4: the middle estimate sits 2 percentage points below what was measured, within the range that was stated.
By their numbers in this assay, from the lowest: compounds 1 and 2 (each within the scatter of the next); then compounds 4 and 3 (each within the scatter of the next).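

In this assay, the step between two five-membered aromatic rings on the saturated ring carbon, with the ethoxycarbonyl group held constant, is a number 1 percentage points lower from compound 3 to compound 4 (within the scatter). Furan-3-yl and thiophen-3-yl therefore cannot be told apart at this position in this pair. No supporting data bear on this result.

Going by these compounds, it remains open whether a phenyl group or an aminomethyl group on this carbon would shift the number. On these data alone, it also remains open whether the same ring swap would stay within the scatter alongside the isopropyl ester of compound 2.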